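This account rests on a few compounds, and the source may have more. Where it says the series, first, only, none or still open, it means among the compounds named here.

Compound 1 `Cc1[nH]c2ccccc2c1C=C(C#N)C#N`: 56000 nM
Compound 2 `N#C/C(=C\c1c(-c2ccccc2)[nH]c2ccccc12)C(=O)Nc1ccc(Cl)cc1`: 1700 nM

Of the compounds shown here, two have so far been measured in a functional assay on MT4 cells (Homo sapiens) for antiproliferative activity, read by MTT assay, with a stated time of 96 h; a higher number here means that more compound is needed for the effect, a lower number that less compound is needed. Compound 1 gives 56000 nM, while compound 2 gives 1700 nM. Compound 2 therefore has the lower of the two numbers, and its gap to compound 1 lies beyond the scatter of repeated measurements. The two compounds differ in more than one place, so the pair says nothing on its own about any single structural change.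

Compound 3 `N#C/C(=C\c1c(-c2ccccc2)[nH]c2ccccc12)C(=O)c1cccs1` has not yet been measured in this assay. It differs from compound 2 in one place: thiophen-2-yl in place of (4-chlorophenyl)amino on a carbonyl carbon. Nothing measured here bears directly on this exchange, so the expectation rests on compound 2 alone, with wide uncertainty. A step of modest size is expected, most likely toward a higher number, though a value within the scatter of compound 2 would not surprise. Compound 3 is therefore estimated to give 3000 nM, with a range from 800 nM to 12000 nM. This estimate means an expected step of a 1.8-fold higher number from compound 2 to compound 3 (0.25 log units; within the scatter).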

Compound 3, half-maximal effective concentration: 400 nM
For compound 3 the middle estimate is 7.5-fold (0.88 log units) above the measured one, and the stated range ends above it.
By their numbers in this assay, from the lowest: compound 3; then compound 2; then compound 1.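

In this assay, putting thiophen-2-yl in place of (4-chlorophenyl)amino on a carbonyl carbon gives a 4.3-fold lower number from compound 2 to compound 3 (0.63 log units; beyond the scatter), the first change in a single place that can be read among these compounds. It shows that the number responds to what sits on this carbonyl carbon, and that neither the (4-chlorophenyl)amino group nor its amide hydrogen is required to reach this level of activity, since the entering group, with fewer heavy atoms and no hydrogen-bond donor, gives the lower number. No measurement is available that explains why this exchange lowers the number.

The exchange removes the nitrogen and swaps the ring in one step, so the compounds shown leave open which of these two differences accounts for the result; a plain phenyl group on the same carbonyl carbon, or a thiophen-2-ylamino group, would begin to separate them. Also open, from the compounds shown here alone, is how far this position tolerates other kinds of group, such as a simple alkyl chain or a saturated amine like morpholine.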